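The source may hold more compounds than are shown below. What is called first, only, known or untested is meant among the compounds shown, and "the series" means these compounds.

Compound 2 `CCc1ccccc1OS(=O)(=O)c1ccc(N2CCN(C)C2=O)cc1` is the point of departure. In a functional assay on M21 cells (Homo sapiens) for antiproliferative activity, read by sulforhodamine B assay, with a stated time of 48 h (a higher number here means a weaker inhibitor, a lower number a stronger inhibitor), compound 2 gives 2300 nM, which is the lowest of the two numbers recorded, and its nearest neighbour is compound 1 `Cc1ccccc1OS(=O)(=O)c1ccc(N2CCN(C)C2=O)cc1`, which in this assay gives 2900 nM; the step of a 1.3-fold lower number from compound 1 to compound 2 (0.10 log units; within the scatter) lies within the scatter, so the two cannot be ranked. Compound 3 `CN1CCN(c2ccc(S(=O)(=O)Oc3ccc(F)cc3)cc2)C1=O` is different in kind: in this assay compound 3 gives only a limit of the assay, > 100000 nM, which is the limit noted as the limit of > 100000 nM in this assay, at which 1 of the 3 values shown sits.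

Compound 4 `CN1CCN(c2ccc(S(=O)(=O)Oc3ccc(Cl)cc3)cc2)C1=O` has not been measured in this assay. It differs from compound 2 by 4-chlorophenyl in place of 2-ethylphenyl on an oxygen. Within the data shown here, the steps that bear on this change are the two in which a 2-alkylphenyl on the sulfonyl oxygen is exchanged for a 4-halophenyl: an at least 34-fold higher number from compound 1 to compound 3 (1.53 log units; beyond the scatter) and an at least 43-fold higher number from compound 2 to compound 3 (1.63 log units; beyond the scatter), both large and both beyond the scatter, each ending at the assay limit.

The expectation for compound 4 is therefore a large step upward in this assay, of the order of a 26-fold higher number from compound 2 to compound 4 (1.42 log units; beyond the scatter), with a fair chance that only a limit is reported. Compound 4 is estimated to give about 60000 nM, within a range of 12000 nM to 200000 nM.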

Compound 4, half-maximal inhibitory concentration: 43000 nM
Beside the measured number, compound 4's estimate is 1.4-fold (0.14 log units) above it, within the range that was stated.
By their numbers in this assay, from the lowest: compounds 2 and 1 (each within the scatter of the next); then compound 4. At a limit, above all of these: compound 3.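

In this assay, the exchange on the oxygen bound to the sulfonyl sulfur can now be sized as a real step rather than only a bound, since compound 4 has a measured number: a 19-fold higher number from compound 2 to compound 4 (1.27 log units; beyond the scatter), and a 15-fold higher number from compound 1 to compound 4 (1.17 log units; beyond the scatter), both large. The 4-halophenyl compounds also do not behave alike, for chloro in place of fluoro on an aromatic carbon gives an at least 2.3-fold lower number from compound 3 to compound 4 (0.36 log units; beyond the scatter), so the halogen changes the outcome even though neither compound comes near the 2-alkylphenyl pair. That step remains open-ended, as the value for compound 3 is a limit of the assay and not a number: the limit of > 100000 nM in this assay, at which 1 of the 4 values shown sits.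

The compounds shown change the group and the place of its substituent together, so a 2-chlorophenyl or a 4-ethylphenyl on this oxygen would be needed to tell whether the place or the kind of substituent accounts for the large steps. On these data alone, how far the halogen trend extends also stays open, since 4-bromophenyl and unsubstituted phenyl do not appear among them.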